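This account rests on a few compounds, and the source may have more. Where it says the series, first, only, none or still open, it means among the compounds named here.

Of the compounds shown here, three have so far been measured in a functional assay on MIA PaCa-2 cells (Homo sapiens) for inhibition, read by MTT assay, with a stated time of 72 h, tested at 50 uM; a lower number here means less inhibition of growth, a higher number more inhibition of growth at the concentration tested. Compound 1 `C=CCc1ccc(OCc2cn(-c3cccc([N+](=O)[O-])c3)nn2)c(O)c1` gives 58.8%. Compound 3 `C=CCc1ccc(OCc2cn(-c3ccccc3CO)nn2)c(O)c1` gives 52.1%. Compound 2 `C=CCc1cc(O)c(O)c(CN2CCC(CCO)CC2)c1` gives 71.8%, the highest of the three numbers, and its distance to each of the other two lies beyond the scatter.

The next compound to be tested starts from compound 2. Compound 4 `C=CCc1cc(O)c(O)c(CN2CCC(Cc3ccccc3)CC2)c1` differs from compound 2 in one place: phenyl in place of hydroxymethyl on a saturated chain carbon bound to a saturated ring carbon. Cut one bond further out, the same difference reads 2-hydroxyethyl to benzyl.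

Going by the values given here, no pair of measured compounds shows this change or any other single change, so the data give no direct measure of its size. The expectation therefore rests on compound 2 at 71.8% as its only close reference, and it carries a wide margin. A modest rise in growth inhibition is expected, an estimated a number 6.2 percentage points higher from compound 2 to compound 4 (within the scatter), and a step of this size may not clear the scatter. The estimated value for compound 4 is 78%, with an expected range of 60% to 95%.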

Compound 4, percent growth inhibition at one concentration: 90.9%
Compound 4: middle estimate off by 12.9 percentage points, on the low side; the range from low to high includes it.
By their numbers in this assay, from the lowest: compounds 3 and 1 (each within the scatter of the next); then compound 2; then compound 4.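

Going by these compounds alone, this is the first step that can be read between two compounds differing in one place: with phenyl in place of hydroxymethyl on a saturated chain carbon bound to a saturated ring carbon, this assay shows a number 19.1 percentage points higher from compound 2 to compound 4 (beyond the scatter), a change that lies beyond the scatter. It shows that this place in the molecule is not indifferent to what it carries, since going from 2-hydroxyethyl to benzyl, which removes a hydrogen-bond donor and acceptor and brings in a six-membered aromatic ring of carbon only, moves the read-out upward. No measurement at hand explains this step.

The compounds shown leave open whether the gain follows the arrival of the aromatic ring or the departure of the hydroxyl, a question that a plain propyl group or a cyclohexylmethyl group at this place would help to separate. They also leave open how far the trend reaches, for instance with a longer chain such as 2-phenylethyl, or with a benzyl group carrying a carboxylic acid or an amine.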